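Compound 3 and the hydroxymethyl change

This account rests on a few compounds, and the source may have more. Where it says the series, first, only, none or still open, it means among the compounds named here.

Among the compounds with values here, in an ADME assay on MT4 cells (Homo sapiens) for cytotoxicity, read by MTT assay (a lower number here means that less compound is tolerated, a higher number that more compound is tolerated), compound 1 `Cc1cc(C)cc(S(=O)(=O)c2c(C(=O)Nc3cccc(O)c3)[nH]c3ccc(Cl)cc23)c1` gives 24600 nM and compound 3 `Cc1cc(C)cc(S(=O)(=O)c2c(C(=O)NCc3ccc(O)cc3)[nH]c3ccc(Cl)cc23)c1` gives 6250 nM as the lowest number measured so far. Compound 2 `Cc1cc(C)cc(S(=O)(=O)c2c(C(=O)NCc3cc(O)ncn3)[nH]c3ccc(Cl)cc23)c1` reads > 53000 nM as a limit of the assay, not a number. Compound 4 `Cc1cc(C)cc(S(=O)(=O)c2c(C(=O)NCc3ccc(CO)cc3)[nH]c3ccc(Cl)cc23)c1` differs from compound 3 by hydroxymethyl in place of hydroxy on an aromatic carbon with hydroxymethyl in place of hydroxy on an aromatic carbon, para to a large group. Within the data shown here, no measured step makes this change. The nearest steps, a 3.9-fold lower number from compound 1 to compound 3 (0.60 log units; beyond the scatter) and an at least 8.4-fold lower number from compound 2 to compound 3 (0.92 log units; beyond the scatter), each alter more of the group on the amide-type nitrogen, so a smaller step is expected here. The expected step is a 1.4-fold higher number from compound 3 to compound 4 (0.16 log units; within the scatter) and it is not expected to pass the scatter. Compound 4 is estimated at 9000 nM with an expected range of 3500 nM to 25000 nM in this assay.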

Compound 4, half-maximal cytotoxic concentration: 31100 nM
Compound 4: the middle estimate sits 3.5-fold (0.54 log units) below what was measured; the whole stated range lies below it.
By their numbers in this assay, from the lowest: compound 3; then compounds 1 and 4 (each within the scatter of the next). At a limit, above all of these: compound 2.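

In this assay, within the data shown here, this is the first step confined to the aromatic carbon para to a large group, and hydroxymethyl in place of hydroxy alone gives a 5.0-fold higher number from compound 3 to compound 4 (0.70 log units; beyond the scatter). 4-(hydroxymethyl)benzyl in place of 3-hydroxyphenyl on the amide-type nitrogen gives a 1.3-fold higher number from compound 1 to compound 4 (0.10 log units; within the scatter). Compound 2 stands at a limit, not a number: the limit of > 53000 nM in this assay, at which 1 of the 4 values shown sits 4-(hydroxymethyl)phenyl in place of 6-hydroxypyrimidin-4-yl on the saturated chain carbon gives an at least 1.7-fold lower number from compound 2 to compound 4 (0.23 log units; that floor lies within the scatter), so this step cannot be read as a difference.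

Going by these compounds, it remains open whether an aminomethyl, a methoxy, a carboxylic acid or a longer hydroxyalkyl chain at this place would track with hydroxymethyl or with hydroxy.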